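The source may hold more compounds than are shown below. What is called first, only, known or untested is meant among the compounds shown, and "the series" means these compounds.

Compound 1, `COc1nc(N)nc2c1c(-c1ccccc1)cn2[C@@H]1O[C@H](CO)[C@@H](O)[C@H]1O`, and compound 2, `C#Cc1cn([C@@H]2O[C@H](CO)[C@@H](O)[C@H]2O)c2nc(N)nc(OC)c12`, share one core and differ only in the group on an aromatic carbon of it. In a functional assay on HeLa S3 cells (Homo sapiens) for antiproliferative activity, read by XTT assay, with a stated time of 72 h (a lower number here means a stronger inhibitor, a higher number a weaker inhibitor), compound 1 gives > 20000 nM, which is a limit of the assay and not a number. In this assay compound 2 likewise gives > 20000 nM, again a limit rather than a number. The step from compound 1 to compound 2, a step that the two limits leave unreadable from compound 1 to compound 2, ethynyl in place of phenyl on an aromatic carbon, cannot be read because both of its ends sit at the limit of > 20000 nM in this assay, at which 2 of the 2 values shown sit. Among the measured compounds shown here, compound 2 thus stands at the limit, as does the one other value shown.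

Compound 3, `COc1nc(N)nc2c1c(-c1ccco1)cn2[C@@H]1O[C@H](CO)[C@@H](O)[C@H]1O`, differs from compound 2 by furan-2-yl in place of ethynyl on an aromatic carbon. For the measured compounds named here, the only measured step that bears on this change is the unreadable one from compound 1 to compound 2, so no size of step is available, and the expectation rests on two values that are both limits. Compound 3 is expected to give 30000 nM in this assay, with a range from 12000 nM to 100000 nM, most probably reported again only as a limit. The step from compound 2 to compound 3 is accordingly estimated as a step that the limit leaves unreadable from compound 2 to compound 3, with no direction beyond the scatter.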

Compound 3, half-maximal inhibitory concentration: > 20000 nM
Compound 3 gave a limit, no number; the forecaster's own chance of this, stated with the estimate: 80%; the middle value does not contradict the limit.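

In this assay compound 3 gives > 20000 nM, which is a limit and not a number. Among the compounds shown here, no new step among compound 1, compound 2 and compound 3 can be read, because all three stand at one limit: the limit of > 20000 nM in this assay, at which 3 of the 3 values shown sit. Going by these compounds, how phenyl, ethynyl and furan-2-yl compare on the shared core remains open.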